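The source may report more compounds than this note shows. Statements on the series, on what has been measured and on what is new or still open speak of the compounds shown alone.

Measured so far:
- Compound 1, `COc1ccc(-c2cn3nc(Cl)sc3n2)cc1`, in an ADME assay on CCRF-CEM cells (Homo sapiens) for cytotoxicity, with a stated time of 72 h; a lower number here means a stronger inhibitor, a higher number a weaker inhibitor: > 250000 nM
- Compound 2, `Clc1ccc(Cc2nn3c(Br)c(-c4ccc(Cl)cc4)nc3s2)cc1`, in this assay: > 250000 nM
- Compound 3, `O=Cc1c(-c2ccc(Cl)cc2)nc2sc(Cc3ccc(Cl)cc3)nn12`, in this assay: 5800 nM

The result for compound 1 is a limit of the assay, not a number. The result for compound 2 is likewise a limit. Compound 3 is thus the only one of the three with a measured number; the other two results sit at the limit of > 250000 nM in this assay, at which 2 of the 3 values shown sit. Among the measured compounds shown here, the one step that can be read between measured compounds is an at least 43-fold lower number from compound 2 to compound 3 (1.63 log units; beyond the scatter), in which a formyl group replaces a bromo group on an aromatic carbon of the shared core.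

Compound 4, `COc1ccc(-c2nc3sc(Cc4ccc(Cl)cc4)nn3c2C=O)cc1`, differs from compound 3 in one place: methoxy in place of chloro on an aromatic carbon. For the measured compounds named here, none of the measured steps changes this part of the molecule, so there is nothing measured that speaks for a shift in either direction. Going by the values given here, with the only comparable step concerning a different position, the expectation for a 1.0-fold higher number from compound 3 to compound 4 (0.01 log units; within the scatter) is a change that stays within the usual scatter. Compound 4 is therefore estimated at 6000 nM, with a plausible range from 1500 nM to 25000 nM.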

Compound 4, half-maximal inhibitory concentration: 3800 nM
Beside the measured number, compound 4's estimate is 1.6-fold (0.20 log units) above it; measured number inside the range.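

In this assay, the swap of 4-chlorophenyl to 4-methoxyphenyl gives a 1.5-fold lower number from compound 3 to compound 4 (0.18 log units; within the scatter), so on this six-membered aromatic ring, para to a large group, the read-out does not separate chloro from methoxy, even though methoxy brings in 1 hydrogen-bond acceptor and chloro brings in none. Among the compounds shown here, this is the first measured change at this position, and it contrasts with an at least 43-fold lower number from compound 2 to compound 3 (1.63 log units; beyond the scatter), a step beyond the scatter at a different place on the shared core, so in these two steps only the formyl-for-bromo change moves the number by more than the scatter. Nothing measured here gives a reason for either step, and a single pair cannot show how tolerant this position is in general.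

The compounds shown leave open whether a quite different group at this same position, such as an amine, a carboxylic acid or a longer chain like butoxy, would also stay within the scatter. They also leave open what an amine or a carboxylic acid would do in the place of the formyl group on the shared core.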